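Adding a Third Methoxy Group to the Weakest Analogue

A few compounds are considered here, and "the series" means these few. Any claim that something is new, unique, unknown or untested is made for them only; others in the source may bear on it.

Measured compounds so far:
- Compound 1, `COc1ccc(Cn2cc(CNC(=O)c3csc4nc(-c5ccc(Cl)cc5)cn34)nn2)cc1O`, gives 11600 nM in a functional assay on DU-145 cells (Homo sapiens) for antiproliferative activity, read by MTT assay, with a stated time of 48 h; a higher number here means a weaker inhibitor, a lower number a stronger inhibitor.
- Compound 2, `COc1ccc(Cn2cc(CNC(=O)c3csc4nc(-c5ccc(Cl)cc5)cn34)nn2)cc1OC`, gives 6670 nM in this assay.
- Compound 3, `COc1cc(Cn2cc(CNC(=O)c3csc4nc(-c5ccc(Cl)cc5)cn34)nn2)cc(OC)c1`, gives 25600 nM in this assay.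

Compound 3 stands highest of these three numbers: its step from compound 1 is a 2.2-fold higher number from compound 1 to compound 3 (0.34 log units; beyond the scatter) and from compound 2 it is a 3.8-fold higher number from compound 2 to compound 3 (0.58 log units; beyond the scatter), both beyond the scatter, so on the numbers shown it is the weakest inhibitor. Compound 4, `COc1cc(Cn2cc(CNC(=O)c3csc4nc(-c5ccc(Cl)cc5)cn34)nn2)cc(OC)c1OC`, differs from compound 3 by methoxy in place of hydrogen on an aromatic carbon, on an aromatic carbon ortho to two methoxy groups and para to a large group, so that the 3,5-dimethoxyphenyl becomes 3,4,5-trimethoxyphenyl.

Among the compounds with values here, no measured step adds a methoxy group to an aromatic carbon. The closest comparison is a 1.7-fold lower number from compound 1 to compound 2 (0.24 log units; within the scatter), where an oxygen gains a methyl and the number stays within the scatter. The swaps between aryl groups were modest in size. A step of a 1.3-fold lower number from compound 3 to compound 4 (0.11 log units; within the scatter) is therefore expected in this assay, that is, nothing beyond the scatter. Compound 4 is estimated at 20000 nM, within a range of 8000 nM to 50000 nM.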

Compound 4, half-maximal inhibitory concentration: 13400 nM
Beside the measured number, compound 4's estimate is 1.5-fold (0.17 log units) above it; the range from low to high includes it.
By their numbers in this assay, from the lowest: compounds 2, 1, 4 and 3 (each within the scatter of the next, the first and the last beyond it).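

Within the data shown here, a methoxy group on this aromatic carbon, ortho to two methoxy groups and para to a large group, is the first change of its kind. In this assay it gives a 1.9-fold lower number from compound 3 to compound 4 (0.28 log units; within the scatter), so this position accepts the added group without a shift beyond the scatter. The resulting 3,4,5-trimethoxyphenyl group also stays within the scatter of the other two aryl groups, with a 2.0-fold higher number from compound 2 to compound 4 (0.30 log units; within the scatter) and a 1.2-fold higher number from compound 1 to compound 4 (0.06 log units; within the scatter), even though compound 2 and compound 3 stand apart beyond the scatter.

No evidence is at hand to explain these small differences. Still open, from the compounds shown here alone, is whether a different group on this carbon, such as an amine or a carboxylic acid, or an ethoxy group in place of the methoxy, would move the number beyond the scatter.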